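The source may hold more compounds than are shown below. What is called first, only, known or untested is meant among the compounds shown, and "the series" means these compounds.

Measured compounds:
compound 1, `CC(=O)c1cc(-c2ccccc2)cc2cc(-c3ccc(F)cc3)[nH]c12`, giving 96.8%
compound 2, `CC(=O)c1cc(/C=C/c2ccc(F)cc2)cc2cc(-c3ccccc3)[nH]c12`, giving 72.2%

The account concerns a functional assay on MCF7 cells (Homo sapiens) for cytotoxicity, read by MTT assay, with a stated time of 2 days, tested at 1 uM (on this read-out higher numbers stand for a weaker effect at the one concentration tested and lower numbers for a stronger effect), in which two compounds sharing a core have been measured. Compound 1 gives 96.8%, while compound 2 gives 72.2%. Of these two numbers, compound 2 stands lowest; the nearest number is that of compound 1, which lies higher by a gap beyond the usual scatter, so the two compounds are distinguished in this assay. Within the data shown here, no single-site step between measured compounds is available, so the effect of the change about to be made has not been observed directly in these data.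

Compound 3, `CC(=O)c1cc(/C=C/c2ccc(F)cc2)cc2cc(-c3ccc(F)cc3)[nH]c12`, has not yet been measured in this assay. It differs from compound 2 in one place: fluoro in place of hydrogen on an aromatic carbon.

Among the measured compounds shown here, nothing among the measured compounds shows what fluoro in place of hydrogen on this aromatic carbon does in this assay. On this basis compound 3 is expected to give 70%, with a range from 52% to 88%. The step of a number 2.2 percentage points lower from compound 2 to compound 3 (within the scatter) is expected to fall within the scatter, with no clear direction.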

Compound 3, a percentage reported as activity, at one concentration (the size of the read-out at that concentration, not a potency): 82%
The estimate for compound 3 lay 12 percentage points below the measured number; the measured number falls inside the stated range.
By their numbers in this assay, from the lowest: compounds 2 and 3 (each within the scatter of the next); then compound 1.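

In this assay, the change from phenyl to 4-fluorophenyl, with fluoro in place of hydrogen on an aromatic carbon para to a large group, gives a number 9.8 percentage points higher from compound 2 to compound 3 (within the scatter), so this read-out does not separate fluoro from hydrogen at this position. With the 4-fluorophenyl group present, the second change, 2-(4-fluorophenyl)ethenyl in place of phenyl on an aromatic carbon, gives a modest step, a number 14.8 percentage points lower from compound 1 to compound 3 (beyond the scatter), and offers the first direct view of that exchange in a single place. Nothing measured here bears on why either step has the size it does.

As far as these compounds go, it remains open whether other groups at the fluoro position, such as chloro, methoxy, an amine or a carboxylic acid, would move the read-out beyond the scatter, or whether this position responds little to substitution in general. Also open is whether the step seen with the 2-(4-fluorophenyl)ethenyl group would persist if a longer chain replaced the ethenyl link, and how any of these compounds would behave at concentrations other than the one tested.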